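This account rests on a few compounds, and the source may have more. Where it says the series, first, only, none or still open, it means among the compounds named here.

Measured compounds:
Compound 1, `COc1ccc(-n2nc(C(N)=O)nc2-c2cc(OC)c(OC)c(OC)c2)cc1`: 59%
Compound 2, `COc1ccc(NC(=O)c2nc(-c3cc(OC)c(OC)c(OC)c3)n(-c3ccc(OC)cc3)n2)cc1`: 45%
Compound 3, `COc1ccc(-n2nc(C(=O)Nc3ccccc3C)nc2-c2cc(OC)c(OC)c(OC)c2)cc1`: 30%

In a functional assay on the whole organism for inhibition, with Rattus norvegicus as the target, read by paw edema, with stated times of 30 min and 2 h, at a dose of 0.28 mmol/kg by the oral route (a lower number here means less inhibition, a higher number more inhibition at the dose given (going by the name of the read-out)), compound 2 gives 45%, the second highest of the three numbers. It stands below compound 1 by the step of a number 14 percentage points lower from compound 1 to compound 2 (beyond the scatter) and above compound 3 by the step of a number 15 percentage points lower from compound 2 to compound 3 (beyond the scatter). Compound 4, `COc1ccc(-n2nc(C(=O)Nc3ccc(C(F)(F)F)cc3)nc2-c2cc(OC)c(OC)c(OC)c2)cc1`, differs from compound 2 in one place: trifluoromethyl in place of methoxy on an aromatic carbon. Among the measured compounds shown here, no measured step makes this exchange; the closest is a number 15 percentage points lower from compound 2 to compound 3 (beyond the scatter), where a different ring on the amide-type nitrogen lowered inhibition, and a number 29 percentage points lower from compound 1 to compound 3 (beyond the scatter) points the same way. A small drop or no change beyond the scatter is therefore expected. Compound 4 is expected to give about 40%, between 22% and 58%. The expected step of a number 5 percentage points lower from compound 2 to compound 4 (within the scatter) is estimated to be slight.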

Compound 4, a percentage reported as inhibition, in the whole organism at one dose (the size of the read-out at that dose, not a potency): 55%
Compound 4: middle estimate off by 15 percentage points, on the low side; low and high end bracket the measured number.
By their numbers in this assay, from the lowest: compound 3; then compounds 2, 4 and 1 (each within the scatter of the next, the first and the last beyond it).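

Trifluoromethyl in place of methoxy on this aromatic carbon gives a number 10 percentage points higher from compound 2 to compound 4 (within the scatter) in this assay, so this exchange cannot be told apart from ordinary scatter. A substituted phenyl on the amide nitrogen does not always lower the number as it did in compound 2 and compound 3: the plain amide gives a number 4 percentage points lower from compound 1 to compound 4 (within the scatter), while the choice of ring still counts, with a number 25 percentage points higher from compound 3 to compound 4 (beyond the scatter). Nothing measured here explains these results.

Going by these compounds, whether an amine or a carboxylic acid on this aromatic carbon would fit the same picture remains open.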